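The source may hold more compounds than are shown below. What is called first, only, known or untested is meant among the compounds shown, and "the series" means these compounds.

Compound 1 `O=C(O)Cn1c(=O)c(Oc2ccc(O)cc2)nc2ccccc21` gives 21.3% in a physicochemical assay, read by spectrophotometry, with a stated time of 240 min, tested at 100 uM; on this read-out higher numbers stand for a stronger effect at the one concentration tested and lower numbers for a weaker effect. Compound 2 `O=C(O)Cn1c(=O)c(Oc2ccc(O)cc2)nc2cc(F)ccc21` gives 23.7% in this assay.

Going by the values given here, of the two numbers so far, compound 1 holds the lower one; its nearest neighbour is compound 2, and the step of a number 2.4 percentage points higher from compound 1 to compound 2 (within the scatter) lies within the scatter, so the two compounds are not distinguished by this read-out. Compound 3 `O=C(O)Cn1c(=O)c(Oc2ccc(O)cc2)nc2ccc(Cl)cc21` is not yet measured. It differs from compound 1 in one place: chloro in place of hydrogen on an aromatic carbon. Among the compounds with values here, the only measured step that bears on this change is the one in which fluoro replaces hydrogen on an aromatic carbon, a number 2.4 percentage points higher from compound 1 to compound 2 (within the scatter), which stayed within the scatter. On that basis compound 3 is expected to show no step beyond the scatter, with a number 1.7 percentage points higher from compound 1 to compound 3 (within the scatter). The number for compound 3 in this assay is therefore estimated at 23%, in a range from 13% to 34%.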

Compound 3, a percentage reported as activity, at one concentration (the size of the read-out at that concentration, not a potency): 84.8%
Compound 3: the middle estimate sits 61.8 percentage points below what was measured; the measured number lies above the stated range.
By their numbers in this assay, from the lowest: compounds 1 and 2 (each within the scatter of the next); then compound 3.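

In this assay, a single chloro on this aromatic carbon, meta to a fused ring and para to a fused ring, gives a number 63.5 percentage points higher from compound 1 to compound 3 (beyond the scatter), showing that the read-out can respond strongly to one heavy atom added to the core of compound 1. Replacing hydrogen with a halogen is therefore not silent across the core, although the fluoro change gave a number 2.4 percentage points higher from compound 1 to compound 2 (within the scatter); compound 2 and compound 3 differ in both the halogen and the aromatic carbon carrying it, so these steps cannot separate the effect of the group from that of the place. No measurement offered here accounts for the size of the chloro step.

On these data alone, it remains open whether fluoro, bromo, methyl or methoxy on this same carbon would match chloro. As far as these compounds go, it also remains open whether chloro on the other aromatic carbons of the core would give a similar step.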